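A few compounds are considered here, and "the series" means these few. Any claim that something is new, unique, unknown or untested is made for them only; others in the source may bear on it.

Measured in a functional assay on T-24 cells (Homo sapiens) for antiproliferative activity, read by MTT assay, with a stated time of 72 h; a lower number here means a stronger inhibitor, a higher number a weaker inhibitor:
- Compound 1 `N=C(NC(=N)NC1CCCC1)Nc1ccc(C(F)(F)F)cc1`: 3700 nM
- Compound 2 `CC(C)NC(=N)NC(=N)Nc1ccc(C(F)(F)F)cc1`: 4800 nM
- Compound 3 `CC(C)CNC(=N)NC(=N)Nc1ccc(C(F)(F)F)cc1`: 3100 nM

Compound 2 is not separated from the other two measured compounds: a 1.3-fold higher number from compound 1 to compound 2 (0.11 log units; within the scatter) and a 1.5-fold lower number from compound 2 to compound 3 (0.19 log units; within the scatter) both lie within the scatter. Compound 4 `CC(C)NC(=N)NC(=N)Nc1ccc(F)cc1` differs from compound 2 by fluoro in place of trifluoromethyl on an aromatic carbon, with fluoro in place of trifluoromethyl on an aromatic carbon. Those steps and a 1.2-fold lower number from compound 1 to compound 3 (0.08 log units; within the scatter) all change the group on an amine nitrogen, so none tests this new place, where every measured compound carries trifluoromethyl. With no direct guide in the data, a moderate move to a higher number in this assay is expected, with wide uncertainty. The expected change is a 2.3-fold higher number from compound 2 to compound 4 (0.36 log units; beyond the scatter). For compound 4 the estimate is 11000 nM, with an expected range from 4500 nM to 35000 nM.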

Compound 4, half-maximal inhibitory concentration: > 50000 nM
Compound 4: only a limit was reported (the forecaster's own chance of this, stated with the estimate: 15%); middle value at least 4.5-fold (0.65 log units) away from the limit.
By their numbers in this assay, from the lowest: compounds 3, 1 and 2 (each within the scatter of the next). At a limit, above all of these: compound 4.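

In this assay, the aromatic carbon proves to be a place where one change separates compounds, which the amine nitrogen changes among compound 1, compound 2 and compound 3 did not show: fluoro in place of trifluoromethyl gives an at least 10-fold higher number from compound 2 to compound 4 (1.01 log units; beyond the scatter). The result for compound 4 is a limit of the assay and not a number: the limit of > 50000 nM in this assay, at which 1 of the 4 values shown sits.

The compounds shown leave open how other groups would fare at this carbon, such as chloro, methyl or methoxy. They also leave open whether fluoro has the same effect with cyclopentyl or isobutyl on the amine nitrogen.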